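Amide in Place of Ester: Cytotoxicity Outlook

The source may report more compounds than this note shows. Statements on the series, on what has been measured and on what is new or still open speak of the compounds shown alone.

Among the compounds with values here, compound 1 `COC(=O)c1ccc2c(ccn2-c2ccc(NC(=O)Nc3ccc(Cl)c(C(F)(F)F)c3)cc2)n1` carries the only number in an ADME assay on HS27 cells (Homo sapiens) for cytotoxicity, read by MTT assay; a lower number here means a stronger inhibitor, a higher number a weaker inhibitor: compound 1 gives 8200 nM. Compound 2 `COC(=O)c1ccc2c(ccn2-c2ccc(NC(=O)Nc3cccc(Cl)c3Cl)cc2)n1` in this assay gives > 10000 nM, which is a limit of the assay (the limit of > 10000 nM in this assay, at which 1 of the 2 values shown sits). The step of an at least 1.2-fold higher number from compound 1 to compound 2 (0.08 log units; that floor lies within the scatter) therefore tells little. Compound 3 `NC(=O)c1ccc2c(ccn2-c2ccc(NC(=O)Nc3ccc(Cl)c(C(F)(F)F)c3)cc2)n1` differs from compound 1 by amino in place of methoxy on a carbonyl carbon. Within the data shown here, no measured step touches the carbonyl carbon, and the single measured step does not move the number beyond the scatter. Compound 3 is thus expected to show no step beyond the scatter, a 1.1-fold higher number from compound 1 to compound 3 (0.04 log units; within the scatter), with an estimated 9000 nM in this assay, between 4000 nM and 20000 nM.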

Compound 3, half-maximal inhibitory concentration: > 10000 nM
Compound 3 was reported as a limit; the forecaster's own chance of this, stated with the estimate: 40%; at least 1.1-fold (0.04 log units) between middle value and limit.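

Amino in place of methoxy on a carbonyl carbon gives an at least 1.2-fold higher number from compound 1 to compound 3 (0.08 log units; that floor lies within the scatter) in this assay, the first measured step at this position. Compound 3 gives > 10000 nM, which is a limit of the assay and not a number. The step thus shows only that this change gives no reading beyond the scatter, and its true size stays unknown, as a second compound now sits at the same limit: the limit of > 10000 nM in this assay, at which 2 of the 3 values shown sit.

The compounds shown leave open whether a carboxylic acid or a methylamino group on this carbonyl carbon would give a number within the range of the assay.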